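This account rests on a few compounds, and the source may have more. Where it says the series, first, only, none or still open, it means among the compounds named here.

Of the compounds shown here, three have been measured in an assay for inhibition of Amine oxidase [flavin-containing] B (Homo sapiens), read by fluorescence, using microsomes, with a stated time of 30 min; on this read-out higher numbers stand for weaker inhibition and lower numbers for stronger inhibition. Compound 1 `CN(C)Cc1cc(=O)oc2cc(OCc3ccc(CO)cc3)ccc12` gives 630 nM. Compound 2 `CN(C)Cc1cccc(COc2ccc3c(CO)cc(=O)oc3c2)c1` gives 54 nM. Compound 3 `Cc1c(C)c2ccc(OCC3CCN(Cc4cccc(OCCCO)c4)CC3)cc2oc1=O` gives 780 nM, the highest number of the three; its gap to compound 1 is within the scatter, while its gap to compound 2 is beyond it. Compound 4 `Cc1c(C)c2ccc(OCC3CCN(CCCO[N+](=O)[O-])CC3)cc2oc1=O` is not yet measured. It differs from compound 3 in one place: 2-(nitrooxy)ethyl in place of 3-(3-hydroxypropoxy)phenyl on a saturated chain carbon bound to an amine nitrogen in a ring. Within the data shown here, no step between measured compounds matches this change, so nothing in the data gives its size or direction; the measured compounds only show that the shared core with various amine-bearing side chains stays in a range spanning compound 2 to compound 3. For compound 4 a number close to that of compound 3 is expected, with a modest shift toward a higher number or none beyond the scatter. The expected step from compound 3 to compound 4 is a 1.9-fold higher number from compound 3 to compound 4 (0.28 log units; within the scatter). Compound 4 is expected to give 1500 nM in this assay, with a range from 400 nM to 6000 nM.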

Compound 4, half-maximal inhibitory concentration: 250 nM
Beside the measured number, compound 4's estimate is 6.0-fold (0.78 log units) above it, outside the stated range (below it).
By their numbers in this assay, from the lowest: compound 2; then compound 4; then compounds 1 and 3 (each within the scatter of the next).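

In this assay, 2-(nitrooxy)ethyl in place of 3-(3-hydroxypropoxy)phenyl on a saturated chain carbon bound to an amine nitrogen in a ring gives a 3.1-fold lower number from compound 3 to compound 4 (0.49 log units; beyond the scatter) and so provides the first measured size and direction for a change at this place. In this one pair, the six-membered aromatic ring of the leaving group is not needed to keep inhibition, since the entering group has no ring and the number still falls. Nothing measured bears on why the number moves.

This single step does not separate the loss of the aromatic ring from the arrival of the nitrooxy group. From the compounds shown here alone, a plain ethyl or 2-hydroxyethyl group at the same place would make that distinction, and whether the step carries over to other amine side chains remains open.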